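A Halogen Swap Tested Twice

This account rests on a few compounds, and the source may have more. Where it says the series, first, only, none or still open, it means among the compounds named here.

Measured so far:
compound 1, `O=S(=O)(/C=C/c1ncccc1F)c1ccccc1F`, gives 176 nM;
compound 2, `O=S(=O)(/C=C/c1ncccc1Cl)c1ccccc1F`, gives 30 nM;
compound 3, `O=S(=O)(/C=C/c1ncccc1F)c1ccc(F)cc1`, gives 542 nM.

All three were tested in an assay on U2OS cells for activation of nuclear factor erythroid 2-related factor 2 (Homo sapiens), read by beta-arrestin recruitment, with a stated time of 6 h; a lower number here means that less compound is needed, a higher number that more compound is needed for the effect. Compound 1 and compound 3 share the same atoms joined differently; the difference between the two cores is not broken down here. Compound 3 stands highest of the three, with compound 1 nearest and compound 2 furthest away.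

Compound 2 arises from compound 1 by chloro in place of fluoro on an aromatic carbon, and that change gave a 5.9-fold lower number from compound 1 to compound 2 (0.77 log units; beyond the scatter). Compound 4, `O=S(=O)(/C=C/c1ncccc1Cl)c1ccc(F)cc1`, is not yet measured. It arises from compound 3 by the same change, (chloro in place of fluoro on an aromatic carbon), made on a core of the same kind at the same place.

Because the earlier step of a 5.9-fold lower number from compound 1 to compound 2 (0.77 log units; beyond the scatter) was clearly beyond the scatter, a step of similar size is expected here, namely a 5.7-fold lower number from compound 3 to compound 4 (0.76 log units; beyond the scatter). Compound 4 is therefore estimated at 95 nM, with a likely range from 35 nM to 250 nM.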

Compound 4, half-maximal effective concentration: 231 nM
The estimate for compound 4 lay 2.4-fold (0.39 log units) below the measured number, within the range that was stated.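

Chloro in place of fluoro gave a 2.3-fold lower number from compound 3 to compound 4 (0.37 log units; beyond the scatter) in this assay, so the number fell on this core as it did on the core of compound 1. Set side by side, the two steps cannot be told apart in size, even though the printed figures look different: the same change on two cores in this assay, a 5.9-fold lower number (0.77 log units; beyond the scatter) from compound 1 to compound 2 and a 2.3-fold lower number (0.37 log units; beyond the scatter) from compound 3 to compound 4, 2.5-fold (0.40 log units) apart, within the scatter of two such steps This supports carrying the change between these two closely related cores, but two cores are a small sample, and the result does not show that the change would behave the same way on a more distant core, nor does it explain why the number falls.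

The compounds shown leave open how a methyl, a methoxy or an amine would compare with chloro at this same place on the ring with the nitrogen. They also leave open whether the swap would still lower the number if the fluoro on the other ring gave way to a carboxylic acid or a nitrile.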